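The source may hold more compounds than are shown below. What is called first, only, known or untested is meant among the compounds shown, and "the series" means these compounds.

Working notes on the carboxylic acid series

Compound 1 `COc1cc2c(cc1OC)C(CC(=O)O)CC2` is the parent acid. In a functional assay on the whole organism (strain Wistar) for inhibition, with Rattus norvegicus as the target, read by paw edema, with stated times of 60 min and 6 h, at a dose of 100 mg/kg by the oral route (on this read-out lower numbers stand for less inhibition and higher numbers for more inhibition at the one dose given (going by the name of the read-out)), compound 1 gives 20.4%, which on paper is the smallest of the three numbers, although neither neighbour is separated from it by more than the scatter: the nearest is compound 3 `CCCCNC(=O)CC1CCc2cc(OC)c(OC)cc21` with 24.1%, the furthest compound 2 `COc1cc2c(cc1OC)C(CC(N)=O)CC2` with 27.8%.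

The measured steps all replace the hydroxy on the carbonyl carbon by a nitrogen-bearing group. a number 7.4 percentage points higher from compound 1 to compound 2 (within the scatter) and a number 3.7 percentage points higher from compound 1 to compound 3 (within the scatter) are both within the scatter, and so is a number 3.7 percentage points lower from compound 2 to compound 3 (within the scatter), where the amide nitrogen carries a butyl instead of hydrogen. Going by the values given here, nothing measured so far moves the read-out beyond the noise.

Compound 4 `COc1cc2c(cc1OC)C(CC(=O)N1CCCCC1)CC2` carries the same change in kind: piperidin-1-yl in place of hydroxy on a carbonyl carbon. Among the compounds with values here, its closest precedent is compound 3, a secondary amide on the same carbonyl carbon; compound 4 closes that nitrogen into a ring and leaves no donor. Since the two amide steps from compound 1 were each within the scatter, no step beyond the scatter is expected here either, in either direction.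

The estimate for compound 4 is therefore 24%, with a range of 12% to 36%, meaning an expected step of a number 3.6 percentage points higher from compound 1 to compound 4 (within the scatter).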

Compound 4, a percentage reported as inhibition, in the whole organism at one dose (the size of the read-out at that dose, not a potency): 31.5%
For compound 4 the middle estimate is 7.5 percentage points below the measured one; measured number inside the range.
By their numbers in this assay, from the lowest: compounds 1, 3, 2 and 4 (each within the scatter of the next, the first and the last beyond it).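

In this assay, going by these compounds alone, piperidin-1-yl gives the first step at this carbonyl carbon that clears the scatter, a number 11.1 percentage points higher from compound 1 to compound 4 (beyond the scatter), so replacing hydroxy at this position can register on the read-out, although the size of the change is modest. This separates compound 4 only from the parent acid, since a number 7.4 percentage points higher from compound 3 to compound 4 (within the scatter) and a number 3.7 percentage points higher from compound 2 to compound 4 (within the scatter) both remain within the scatter, and the ring therefore cannot be ranked above the butylamino or amino groups. Nothing available on these compounds accounts for the step.

The series leaves open whether the step belongs to the piperidine ring itself or would also appear with an open-chain diethylamino group or a morpholin-4-yl ring in the same place. It also leaves open how a methyl ester on the same carbonyl carbon would compare with the acid and the amides on this read-out.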